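The source may report more compounds than this note shows. Statements on the series, on what has been measured and on what is new or still open speak of the compounds shown alone.

Measured so far in a functional assay on MCF7 cells (Homo sapiens) for inhibition, read by resazurin assay, with a stated time of 72 h; on this read-out lower numbers stand for stronger inhibition and higher numbers for weaker inhibition:

- compound 1 `Fc1ccc(-c2ccc(-n3cc(-c4ccccc4)nn3)cc2)cn1`: "not determined" (no result reported).
- compound 2 `CS(=O)(=O)c1cccc(-c2ccc(-n3cc(-c4ccccc4)nn3)cc2)c1`: < 50000 nM.
- compound 3 `N#Cc1cncc(-c2ccc(-n3cc(-c4ccccc4)nn3)cc2)c1`: < 50000 nM.

Compound 1 has no number in this assay; its entry reads "not determined" (no result reported). For compound 2 the entry is a limit of the assay, < 50000 nM, not a number. For compound 3 the entry is likewise a limit, < 50000 nM. Among the compounds with values here, two of the three entries therefore sit at the limit of < 50000 nM in this assay, at which 2 of the 3 values shown sit, and no measured step between any two compounds can be drawn.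

Compound 4 `Clc1ccccc1-c1ccc(-n2cc(-c3ccccc3)nn2)cc1` differs from compound 1 by 2-chlorophenyl in place of 6-fluoropyridin-3-yl on an aromatic carbon. With no number for compound 1, no direction or size of step in this assay can be stated for this change.

Within the data shown here, compound 4 is expected near 25000 nM, between 5000 nM and 50000 nM, because the series so far shows only (the limit of < 50000 nM in this assay, at which 2 of the 3 values shown sit).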

Compound 4, half-maximal inhibitory concentration: < 50000 nM
Compound 4: only a limit was reported; the forecaster's own chance of this, stated with the estimate: 60%; the middle value does not contradict the limit.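

Within the data shown here, compound 4 gives < 50000 nM in this assay, a limit and not a number, so no step from compound 1 or compound 3 to compound 4 can be read. The compounds shown leave open whether compound 2, compound 3 and compound 4 differ at all in this assay: the limit of < 50000 nM in this assay, at which 3 of the 4 values shown sit.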